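Lengthening the Amine Chain: From Ethylamino to Propylamino

A few compounds are considered here, and "the series" means these few. Any claim that something is new, unique, unknown or untested is made for them only; others in the source may bear on it.

In a functional assay on HEK293 cells for agonist activity at 5-hydroxytryptamine receptor 7 (Homo sapiens), read by cAMP accumulation, with a stated time of 30 min (on this read-out lower numbers stand for smaller maximal responses and higher numbers for larger maximal responses), compound 3 `CCNCc1ccc(Cl)c(-c2ccccc2OC)c1` gives 71%, the higher of the two numbers recorded so far. For the measured compounds named here, its nearest neighbour, compound 2 `COc1ccccc1-c1cc(C2CCNC2)ccc1Cl`, gives 29%, and the single step between measured compounds that differ in one place, a number 42 percentage points higher from compound 2 to compound 3 (beyond the scatter), leads to compound 3. Compound 1 `CCCN(CCC)Cc1ccc(Cl)c(-c2ccccc2OC)c1`, whose amine bears two propyl groups, is reported as "not active" (no number reported) in this assay, so no number stands for it.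

Compound 4 `CCCNCc1ccc(Cl)c(-c2ccccc2OC)c1` has not yet been measured. It differs from compound 3 by methyl in place of hydrogen on a saturated chain carbon, two bonds along the chain from an amine nitrogen. Going by the values given here, no measured step adds a single methyl in this way, so nothing bears directly on it. Among the compounds with values here, what the data show is that the compound with the smallest amine substituent, compound 3, gives the largest response, while compound 1 with two propyl groups gives none that could be quantified; the one measured step is large. On that footing the move from ethylamino to propylamino is expected to lower the maximal response modestly, by a number 16 percentage points lower from compound 3 to compound 4 (beyond the scatter), though a step within the scatter cannot be excluded. Compound 4 is therefore estimated to give 55% in this assay, with a likely range from 30% to 80%.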

Compound 4, largest response reached (Emax), in percent of the reference or control that the assay uses: 68%
Estimate against measurement, compound 4: 13 percentage points below; the range from low to high includes it.
By their numbers in this assay, from the lowest: compound 2; then compounds 4 and 3 (each within the scatter of the next).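

In this assay, the change from ethylamino to propylamino gives a number 3 percentage points lower from compound 3 to compound 4 (within the scatter) on going one carbon further out along the chain, so this position takes the added methyl with no shift that stands out from the scatter. The large gain over the pyrrolidin-3-yl compound also survives the longer chain, with a number 39 percentage points higher from compound 2 to compound 4 (beyond the scatter) for the same kind of exchange on the aromatic carbon, which means the earlier large step was not confined to ethylamino. The missing response of compound 1, with two propyl groups on the amine, therefore does not go with the propyl chain as such, since compound 4, with one propyl group on that nitrogen, gives 68% in this same test.

The compounds shown leave open how far the chain can grow, as butylamino or pentylamino would test, and whether a branched isopropylamino or a second, smaller group such as methyl on the same nitrogen would keep the response. No measurement at hand accounts for any of these numbers.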